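Turning the fluorine to the other face of the acid chain

This account rests on a few compounds, and the source may have more. Where it says the series, first, only, none or still open, it means among the compounds named here.

Of the compounds shown here, three sharing one core have been measured in a functional assay on HEK293 cells for agonist activity at Free fatty acid receptor 1 (Rattus norvegicus), read by FLIPR and calcium flux; on this read-out higher numbers stand for an effect only at larger amounts of compound and lower numbers for an effect already at smaller amounts. Compound 1 `COc1ccc(F)c([C@H]2CC[C@H](COc3cccc([C@@H](CC(=O)O)C4CC4)c3)CC2)c1` gives 4.1 nM. Compound 2 `COc1ccc(F)c([C@H]2CC[C@H](COc3cccc([C@H](C4CC4)[C@H](C)C(=O)O)c3)CC2)c1` gives 0.4 nM, a step of a 10-fold lower number from compound 1 to compound 2 (1.01 log units; beyond the scatter). Compound 3 `COc1ccc(F)c([C@H]2CC[C@H](COc3cccc([C@H](C4CC4)[C@H](F)C(=O)O)c3)CC2)c1` gives 163 nM, the highest number of the three: it stands a 40-fold higher number from compound 1 to compound 3 (1.60 log units; beyond the scatter) and a 410-fold higher number from compound 2 to compound 3 (2.61 log units; beyond the scatter). Compound 4 `COc1ccc(F)c([C@H]2CC[C@H](COc3cccc([C@H](C4CC4)[C@@H](F)C(=O)O)c3)CC2)c1` is not yet measured. It differs from compound 3 only in how one centre is drawn: the two compounds have the same atoms and bonds and differ only in configuration as drawn: 1 of 4 stereo elements differ; a stereocentre at a saturated chain carbon is drawn S in compound 3 and R in compound 4. Among the compounds with values here, no measured step changes configuration alone, so none bears directly on this step. The two steps that put fluoro on this carbon, a 40-fold higher number from compound 1 to compound 3 (1.60 log units; beyond the scatter) and a 410-fold higher number from compound 2 to compound 3 (2.61 log units; beyond the scatter), show that this carbon is sensitive to what sits on it, which makes a change in its arrangement likely to matter, but the direction is open. The expectation for compound 4 is therefore a step of a 4.1-fold lower number from compound 3 to compound 4 (0.61 log units; beyond the scatter), with a wide range. Compound 4 is estimated at 40 nM, between 4 nM and 400 nM.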

Compound 4, half-maximal effective concentration: 28 nM
Estimate against measurement, compound 4: 1.4-fold (0.15 log units) above; measured number inside the range.
By their numbers in this assay, from the lowest: compound 2; then compound 1; then compound 4; then compound 3.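

Turning the fluorine to the other face alone gives a step of a 5.8-fold lower number from compound 3 to compound 4 (0.77 log units; beyond the scatter). That shift belongs to this single centre, because nothing else separates the two structures: the fact that compounds 3 and 4 differ only in the configuration as drawn. Even in the better arrangement, fluoro does not match hydrogen or methyl on this carbon, with a step of a 6.8-fold higher number from compound 1 to compound 4 (0.83 log units; beyond the scatter) and another of a 70-fold higher number from compound 2 to compound 4 (1.85 log units; beyond the scatter), so the change of arrangement recovers only part of the loss seen with fluoro.

The compounds shown leave open whether methyl on this carbon is as sensitive to its arrangement as fluoro, as only one methyl arrangement appears here. Also open, going by these compounds, is how a hydroxyl or an ethyl group on this carbon would compare, and whether its two arrangements would differ in the same direction.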